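Chloro in place of hydrogen on compound 1

A few compounds are considered here, and "the series" means these few. Any claim that something is new, unique, unknown or untested is made for them only; others in the source may bear on it.

Measured in an ADME assay on HEK293 cells (Homo sapiens) for cytotoxicity, read by MTT assay, with a stated time of 48 h; on this read-out higher numbers stand for weaker inhibition and lower numbers for stronger inhibition:
- compound 1 `CN(C)CCn1c(N)c(-c2nc3ccccc3[nH]2)c2nc(C#N)c(C#N)nc21`: 9730 nM
- compound 2 `CCN(CC)CCn1c(N)c(-c2nc3ccccc3[nH]2)c2nc(C#N)c(C#N)nc21`: 12200 nM
- compound 3 `CCCCn1c(N)c(-c2nc3ccccc3[nH]2)c2nc(C#N)c(C#N)nc21`: > 50000 nM (a limit of the assay, not a number)

Compound 1 and compound 2 lie within the scatter of each other, with a 1.3-fold higher number from compound 1 to compound 2 (0.10 log units; within the scatter). Only compound 3 stands at a limit. The other two measured steps reach that limit and lie beyond the scatter: an at least 5.1-fold higher number from compound 1 to compound 3 (0.71 log units; beyond the scatter) and an at least 4.0-fold higher number from compound 2 to compound 3 (0.61 log units; beyond the scatter).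

Compound 4 `CN(C)CCn1c(N)c(-c2nc3cc(Cl)ccc3[nH]2)c2nc(C#N)c(C#N)nc21` differs from compound 1 by chloro in place of hydrogen on an aromatic carbon. All three measured steps change the group on the chain, and compound 4 keeps the chain of compound 1. None of them touches an aromatic carbon, so none gives a size for this change. In this assay, no step beyond the scatter is therefore expected, and no direction is favoured, with compound 1 at 9730 nM as the anchor. The expected step is a 1.2-fold lower number from compound 1 to compound 4 (0.09 log units; within the scatter). The estimate for compound 4 is 8000 nM, with an expected range of 3000 nM to 22000 nM.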

Compound 4, half-maximal inhibitory concentration: > 50000 nM
Compound 4: only a limit was reported; the forecaster's own chance of this, stated with the estimate: 4%; middle value at least 6.2-fold (0.79 log units) away from the limit.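

In this assay, among these compounds, chloro in place of hydrogen on an aromatic carbon gives an at least 5.1-fold higher number from compound 1 to compound 4 (0.71 log units; beyond the scatter), so a change on the six-membered aromatic ring of carbon only, a site no earlier step touched, can move this read-out beyond the scatter while the chain of compound 1 stays in place. Compound 4 gives > 50000 nM, which is a limit of the assay and not a number. The step is therefore a lower bound, and its full size cannot be read from this series: the limit of > 50000 nM in this assay, at which 2 of the 4 values shown sit.

On these data alone, whether the same step would follow from another group on this aromatic carbon, such as fluoro, methoxy or an amine, remains open. As far as these compounds go, it also remains open whether chloro would give a similar step with the diethylamino group of compound 2 on the chain.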